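This account rests on a few compounds, and the source may have more. Where it says the series, first, only, none or still open, it means among the compounds named here.

Working notes on the series. Compound 1 `OC[C@@H]1[C@@H](O)[C@@H](O)CN1Cc1cccc2cccnc12` and compound 2 `OC[C@@H]1[C@@H](O)[C@@H](O)CN1Cc1c[nH]c2c(O)ncnc12` share the same core and differ only in the aromatic part attached to it. In an ADME assay on MRC5 cells (Homo sapiens) for cytotoxicity, with a stated time of 48 h (on this read-out higher numbers stand for weaker inhibition and lower numbers for stronger inhibition), compound 1 gives > 64000 nM, which is a limit of the assay rather than a number. In this assay compound 2 likewise gives > 64000 nM, again a limit rather than a measured number. Among the measured compounds shown here, compound 2 therefore stands at the same point as the only other value shown: the limit of > 64000 nM in this assay, at which 2 of the 2 values shown sit. For the measured compounds named here, no step between two measured compounds can be stated from these numbers; the two values show only that neither compound reached a measurable effect in this assay.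

Compound 3 `Nc1ncnc2c(CN3C[C@H](O)[C@H](O)[C@H]3CO)c[nH]c12` is the next analogue, still to be measured in this assay. It differs from compound 2 by one atom: amino in place of hydroxy on an aromatic carbon.

Given that compound 2 sits at the limit > 64000 nM, the step from compound 2 to compound 3 in this assay is expected to be none beyond the scatter, i.e. a step that the limit leaves unreadable from compound 2 to compound 3 is expected to be flat. Compound 3 is estimated at 100000 nM, with a range of 50000 nM to 250000 nM, and most probably the assay will again return only a limit.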

Compound 3, half-maximal inhibitory concentration: > 64000 nM
Compound 3: a limit, no number; the forecaster's own chance of this, stated with the estimate: 85%; the middle value lies beyond the limit too.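

In this assay compound 3 gives > 64000 nM, which is a limit of the assay and not a number. Among the compounds shown here, compound 2 also stands at a limit, so no step between compound 2 and compound 3 can be read. The compounds shown leave open how amino and hydroxy on that aromatic carbon compare in this assay.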